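The source may report more compounds than this note shows. Statements on the series, on what has been measured and on what is new or still open speak of the compounds shown alone.

Compound 1 `Nc1cccc(CO[C@@H]2C[C@@H]3[C@H]([C@]2(N)C(=O)O)[C@@]3(F)C(=O)O)c1` gives 15.4 nM in an assay on CHO cells for binding affinity to metabotropic glutamate receptor 2 (Rattus norvegicus); on this read-out lower numbers stand for stronger inhibition and higher numbers for weaker inhibition; compound 2 `N[C@]1(C(=O)O)[C@H]2[C@@H](C[C@H]1OCc1cc(F)cc(F)c1)[C@]2(F)C(=O)O` gives 12.4 nM in this assay; compound 3 `N[C@]1(C(=O)O)[C@H]2[C@@H](C[C@H]1OCc1cc(Cl)cc(Cl)c1)[C@]2(F)C(=O)O` gives 5.61 nM in this assay.

Compound 3 stands lowest of the three, with a 2.2-fold lower number from compound 2 to compound 3 (0.34 log units; beyond the scatter) and a 2.7-fold lower number from compound 1 to compound 3 (0.44 log units; beyond the scatter), both beyond the scatter. Compound 4 `N[C@]1(C(=O)O)[C@H]2[C@@H](C[C@H]1OCc1ccc(Cl)cc1Cl)[C@]2(F)C(=O)O` differs from it by 2,4-dichlorophenyl in place of 3,5-dichlorophenyl on a saturated chain carbon bound to an oxygen on a saturated carbon. Within the data shown here, none of the measured steps tests such a change: each of them, a 1.2-fold lower number from compound 1 to compound 2 (0.09 log units; within the scatter) included, exchanges one set of substituents for another rather than moving the same substituents around the ring, so no measured step bears directly on it. With no guide in the data, the expectation for compound 4 is a modest rise in this assay toward the values of compound 1 and compound 2, a 2.1-fold higher number from compound 3 to compound 4 (0.33 log units; beyond the scatter). Compound 4 is therefore estimated at 12 nM, within 4 nM to 40 nM.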

Compound 4, inhibition constant: 3.89 nM
For compound 4 the middle estimate is 3.1-fold (0.49 log units) above the measured one; the measured number lies below the stated range.
By their numbers in this assay, from the lowest: compounds 4 and 3 (each within the scatter of the next); then compounds 2 and 1 (each within the scatter of the next).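

Exchanging 3,5-dichlorophenyl for 2,4-dichlorophenyl on this saturated chain carbon bound to an oxygen gives a 1.4-fold lower number from compound 3 to compound 4 (0.16 log units; within the scatter) in this assay, so these two arrangements of the same two chlorines are not told apart here. The 2,4-dichlorophenyl compound also keeps clear of the other two, with a 3.2-fold lower number from compound 2 to compound 4 (0.50 log units; beyond the scatter) and a 4.0-fold lower number from compound 1 to compound 4 (0.60 log units; beyond the scatter) on this read-out. Nothing measured here accounts for these numbers. The compounds shown leave open how a single chlorine, a bromine or a methoxy group would read at this place, and whether a longer chain would hold these values.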